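Swapping the fluorine for a hydroxy-methoxy pattern

The compounds below may be only part of what the source reports. "The series", "measured", "known", "first", "only" and "open" are said of these compounds alone.

Values measured in a functional assay on MCF cells (Homo sapiens) for antiproliferative activity, with a stated time of 72 h; a lower number here means a stronger inhibitor, a higher number a weaker inhibitor:
- compound 1, `OC[C@H]1O[C@@H](n2cnc3c(NCc4ccccc4F)ncnc32)[C@H](O)[C@@H]1O`: > 166000 nM, a limit of the assay, not a number
- compound 2, `OC[C@H]1O[C@@H](n2cnc3c(NCc4cccc(F)c4)ncnc32)[C@H](O)[C@@H]1O`: 15300 nM
- compound 3, `OC[C@H]1O[C@@H](n2cnc3c(NCc4ccc(F)c(Cl)c4)ncnc32)[C@H](O)[C@@H]1O`: > 166000 nM, again a limit of the assay

All three compounds share the same core and differ only in the ring attached on a saturated chain carbon bound to a nitrogen on an aromatic ring. Compound 1 stands at the limit of the assay, so only an edge is known for it, and the limit of > 166000 nM in this assay, at which 2 of the 3 values shown sit, shows that compound 3 shares that edge. Among the measured compounds shown here, the one readable step is an at least 10-fold lower number from compound 1 to compound 2 (1.03 log units; beyond the scatter), which shows that moving the fluorine within the ring can pull the number down into the measurable range, while an at least 10-fold higher number from compound 2 to compound 3 (1.03 log units; beyond the scatter) pushes it back to the limit.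

Compound 4, `COc1cccc(CNc2ncnc3c2ncn3[C@@H]2O[C@H](CO)[C@@H](O)[C@H]2O)c1O`, is not yet measured. It differs from compound 1 by 2-hydroxy-3-methoxyphenyl in place of 2-fluorophenyl on a saturated chain carbon bound to a nitrogen on an aromatic ring. For the measured compounds named here, no measured step at this place involves a hydroxy or methoxy group, so the only guidance is that ring changes here have been large in both directions. Compound 4 is therefore expected to give an estimate of 120000 nM, within 20000 nM to 500000 nM. That expectation means a step of an at least 1.3-fold lower number from compound 1 to compound 4 (0.14 log units; that floor lies within the scatter), with a real chance that only a limit is reported again.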

Compound 4, half-maximal inhibitory concentration: 20200 nM
For compound 4 the middle estimate is 5.9-fold (0.77 log units) above the measured one, and the stated range covers the measured number.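

In this assay, 2-hydroxy-3-methoxyphenyl on the saturated chain carbon gives a measurable number where 2-fluorophenyl and 3-chloro-4-fluorophenyl do not, with an at least 8.2-fold lower number from compound 1 to compound 4 (0.91 log units; beyond the scatter) and an at least 8.2-fold lower number from compound 3 to compound 4 (0.91 log units; beyond the scatter). Both of these steps start from a limit of the assay and not from a number: the limit of > 166000 nM in this assay, at which 2 of the 4 values shown sit.

The third step is a 1.3-fold higher number from compound 2 to compound 4 (0.12 log units; within the scatter), so among the compounds shown, a ring with no fluorine at all reaches the same measurable range as 3-fluorophenyl, the only fluorinated ring that gave a number, and a fluorine on this ring is therefore not required for a measurable result.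

The compounds shown do not separate the hydroxy group from the methoxy group, as the two appear only together in one ring, so the contribution of each to the result stays unknown. Also open, going by these compounds, is whether an amine or a carboxylic acid on the ring, or a longer chain linking the ring to the nitrogen, would give a lower number than those seen so far.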